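Adding a Chloro Group to Compound 2

The compounds below may be only part of what the source reports. "The series", "measured", "known", "first", "only" and "open" are said of these compounds alone.

In a functional assay on Bel-7402 cells (Homo sapiens) for inhibition, read by MTT assay, with a stated time of 24 h, tested at 100 ug/mL (a lower number here means less inhibition of growth, a higher number more inhibition of growth at the concentration tested), compound 1 (`O=C(CCCCC(S)CCS)Nc1cccc(Cl)c1`) gives 16.1%. Compound 2 (`O=C(CCCCC(CCSC(=O)c1ccccc1)SC(=O)c1ccccc1)Nc1ccccc1`) is reported only as "not active" (no number reported), so it has no single number to stand on. Compound 3 (`O=C(CCCCC(CCSC(=O)c1ccccc1)SC(=O)c1ccccc1)Nc1ccc(Cl)cc1`) is the next structure to be tested. The change is chloro in place of hydrogen on an aromatic carbon, para to a large group. Within the data shown here, no measured step shows what such a change does, so no step beyond the usual scatter is expected in this assay, and inhibition should stay low. Compound 3 is estimated at 8%, with an expected range of 0% to 22%.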

Compound 3, percent growth inhibition at one concentration: "not active" (no number reported)
No number was reported for compound 3, and the estimate cannot be compared.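

Compound 2 and compound 3 are both reported as not active in this assay, and no step can be read between them. The compounds shown leave open what the change from phenyl to 4-chlorophenyl does in this assay. No other data bear on this result.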